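Compound 3: methoxy in place of cyano

A few compounds are considered here, and "the series" means these few. Any claim that something is new, unique, unknown or untested is made for them only; others in the source may bear on it.

In a functional assay on A549 cells (Homo sapiens) for cytotoxicity, read by MTT assay, with a stated time of 72 h (on this read-out higher numbers stand for weaker inhibition and lower numbers for stronger inhibition), compound 2 `COc1cc2ncnc(Nc3ccc(F)c(Cl)c3)c2cc1NC(=O)N/N=C/c1ccc(C#N)cc1` gives 32200 nM and compound 1 `N#Cc1ccc(/C=N/NC(=O)Nc2cc3c(Nc4ccc(F)c(Cl)c4)ncnc3cc2O[C@H]2CCOC2)cc1` gives 29100 nM. These two values lie within the scatter of each other, so compound 2 has no separate rank in this pair.

Compound 3 `COc1ccc(/C=N/NC(=O)Nc2cc3c(Nc4ccc(F)c(Cl)c4)ncnc3cc2OC)cc1` differs from compound 2 at one place: methoxy in place of cyano on an aromatic carbon. This is methoxy in place of cyano on an aromatic carbon, para to a large group, so 4-cyanophenyl becomes 4-methoxyphenyl.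

For the measured compounds named here, only one measured step is available: a 1.1-fold higher number from compound 1 to compound 2 (0.04 log units; within the scatter). It is methyl in place of oxolan-3-yl on an oxygen on an aromatic ring, so it lies elsewhere in the structure and bears on the new change only indirectly. Going by the values given here, no measured pair covers the cyano position.

With no measured evidence for a shift, no step beyond the scatter is expected in this assay, and no direction is favoured. The expected size is a 1.1-fold lower number from compound 2 to compound 3 (0.03 log units; within the scatter). For compound 3 the estimated value is 30000 nM, with an expected range of 12000 nM to 75000 nM.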

Compound 3, half-maximal inhibitory concentration: 28100 nM
Beside the measured number, compound 3's estimate is 1.1-fold (0.03 log units) above it, and the stated range covers the measured number.
By their numbers in this assay, from the lowest: compounds 3, 1 and 2 (each within the scatter of the next).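

In this assay, replacing the nitrile with methoxy on this aromatic carbon, para to a large group, gives a 1.1-fold lower number from compound 2 to compound 3 (0.06 log units; within the scatter). For the compounds shown here, this is the first measured change at this place, as the earlier step, a 1.1-fold higher number from compound 1 to compound 2 (0.04 log units; within the scatter), concerned only the group on the oxygen, with methyl in place of oxolan-3-yl. Among these three compounds, neither single change separates the values beyond the scatter, and no measurement on hand offers an explanation for this result.

Cyano and methoxy have the same count of 2 heavy atoms, with no ring and no net charge, so this pair samples only a narrow range of groups at this carbon, and it remains open whether a group of another kind, such as an amine, a carboxylic acid or a longer chain, would move the number in this assay beyond the scatter. It is also open whether 4-methoxyphenyl would give a similar result alongside oxolan-3-yl on the oxygen, as that combination is absent from the compounds shown here.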